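Aryl ketone variation on the shared pyrazole-chalcone core

This account rests on a few compounds, and the source may have more. Where it says the series, first, only, none or still open, it means among the compounds named here.

Measured compounds:
compound 1 `COc1cc(-c2cc(/C=C/C(=O)c3ccc(N)cc3)[nH]n2)cc(OC)c1OC` gives 105% in a functional assay on NCI-H23 cells (Homo sapiens) for cytotoxicity, read by sulforhodamine B assay, with a stated time of 48 h, tested at 0.1 uM; a lower number here means a stronger effect, a higher number a weaker effect of the compound at the concentration tested
compound 2 `COc1cc(-c2cc(/C=C/C(=O)c3ccc(Cl)c(Cl)c3)[nH]n2)cc(OC)c1OC` gives 92% in this assay
compound 3 `COc1ccc(-c2cc(/C=C/C(=O)c3ccc(N)cc3)[nH]n2)cc1OC` gives 103% in this assay

Compound 2 stands lowest of the three numbers in this assay; compound 3 stands nearest to it and compound 1 furthest, both beyond the scatter. Compound 4 `COc1ccc(C(=O)/C=C/c2cc(-c3cc(OC)c(OC)c(OC)c3)n[nH]2)cc1` is not yet measured and differs from compound 2 by 4-methoxyphenyl in place of 3,4-dichlorophenyl on a carbonyl carbon. Going by the values given here, the only measured step at the same place is a number 13 percentage points lower from compound 1 to compound 2 (beyond the scatter), a modest one; the step of a number 2 percentage points lower from compound 1 to compound 3 (within the scatter) sits elsewhere and is within the scatter. Among the compounds with values here, no measured pair compares 4-methoxyphenyl with either aryl group, so the direction rests on compound 2 being the sole compound set apart from the others. Compound 4 is therefore expected to move back toward compounds 1 and 3, an upward step of a number 8 percentage points higher from compound 2 to compound 4 (within the scatter), possibly within the scatter. The estimate for compound 4 is 100%, ranging from 88% to 112%.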

Compound 4, a percentage reported as activity, at one concentration (the size of the read-out at that concentration, not a potency): 92%
Compound 4: middle estimate off by 8 percentage points, on the high side, within the range that was stated.
By their numbers in this assay, from the lowest: compounds 2 and 4 (each within the scatter of the next); then compounds 3 and 1 (each within the scatter of the next).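

In this assay, the aryl position on the carbonyl carbon gives no change at the digits printed from compound 2 to compound 4 (within the scatter), so the reading of compound 2 is not particular to 3,4-dichlorophenyl: 4-methoxyphenyl, with its different atoms and one hydrogen-bond acceptor, cannot be told apart from it. Methoxy in place of amino gives a number 13 percentage points lower from compound 1 to compound 4 (beyond the scatter), so two different aryl groups now stand apart from 4-aminophenyl.

As far as these compounds go, whether a carboxylic acid or a dimethylamino group on the aryl ring would read with compound 1 or with compound 2 and compound 4 remains open. No accompanying measurement bears on these readings.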